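This account rests on a few compounds, and the source may have more. Where it says the series, first, only, none or still open, it means among the compounds named here.

In an ADME assay on J774.A1 cells (Mus musculus) for cytotoxicity, read by MTT assay, with a stated time of 48 h (on this read-out higher numbers stand for lower toxicity in this test and lower numbers for higher toxicity in this test), compound 1 `O=C(NCc1ccc(F)cc1)c1c([N+](=O)[O-])noc1-c1ccc([N+](=O)[O-])cc1` offers no single number, as its result reads "not determined" (no result reported). Among the compounds with values here, the only measured relative is compound 2 `COc1ccc(CNC(=O)c2c([N+](=O)[O-])noc2-c2ccc([N+](=O)[O-])cc2)cc1`, which gives 69600 nM. Compound 3 `O=C(NCc1ccc(F)cc1)c1c([N+](=O)[O-])noc1-c1ccc(Cl)cc1Cl` differs from compound 1 in one place, with 2,4-dichlorophenyl in place of 4-nitrophenyl on an aromatic carbon. Within the data shown here, no measured pair shows what such a swap does in this assay, so no step beyond the usual scatter, in either direction, is expected from the reading for compound 2 at 69600 nM. For compound 3 the estimated value is 60000 nM, with an expected range of 15000 nM to 200000 nM.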

Compound 3, half-maximal cytotoxic concentration: 86400 nM
The estimate for compound 3 lay 1.4-fold (0.16 log units) below the measured number; the measured number falls inside the stated range.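

In this assay compound 1 has no number to set against compound 3, so no step can be read. What swapping 4-nitrophenyl for 2,4-dichlorophenyl does to the read-out stays open, and nothing shown here points to any cause.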